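Substituent change on the ring nitrogen, compound 1 to compound 3

The source may hold more compounds than are shown below. What is called first, only, known or untested is meant among the compounds shown, and "the series" means these compounds.

Among the measured compounds shown here, compound 1 `CCOC(=O)C1=Cc2ccccc2OC1(OCc1cn(-c2ccc(F)cc2)nn1)C(F)(F)F` is the only member of this pair with a numerical reading: in a functional assay on MCF7 cells (Homo sapiens) for inhibition, read by MTT assay, with a stated time of 24 h (on this read-out higher numbers stand for weaker inhibition and lower numbers for stronger inhibition), compound 1 gives 9100 nM. Compound 2 `CCOC(=O)C1=Cc2ccccc2OC1(OCc1cc(-c2ccc([N+](=O)[O-])cc2)no1)C(F)(F)F` is the other member, and in this assay compound 2 gives > 150000 nM, which is a limit of the assay and not a number. Compound 1 therefore stands alone with a number; the second value shown is a limit (the limit of > 150000 nM in this assay, at which 1 of the 2 values shown sits). For the measured compounds named here, compound 1 and compound 2 differ in more than one place; no step between them is computed, and only their two values can be set side by side.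

Compound 3 `CCOC(=O)C1=Cc2ccccc2OC1(OCc1cn(CC(=O)Nc2cccc(F)c2)nn1)C(F)(F)F` is not yet measured. It differs from compound 1 in one place: ((3-fluorophenyl)carbamoyl)methyl in place of 4-fluorophenyl on an aromatic nitrogen. Going by the values given here, no measured step of this kind exists, so the size of the change cannot be anchored on evidence; the expectation is a step none beyond the scatter, with no direction favoured. Compound 3 is estimated at 9000 nM in this assay, with a range of 2500 nM to 40000 nM. The expected step of a 1.0-fold lower number from compound 1 to compound 3 (0.00 log units; within the scatter) is accordingly small.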

Compound 3, half-maximal inhibitory concentration: > 150000 nM
Compound 3: only a limit was reported; the forecaster's own chance of this, stated with the estimate: 15%; at least 16-fold (1.22 log units) between middle value and limit.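

Among the compounds shown here, this is the first measured step on the aromatic nitrogen of the five-membered ring, and in this assay placing ((3-fluorophenyl)carbamoyl)methyl there in place of 4-fluorophenyl gives an at least 16-fold higher number from compound 1 to compound 3 (1.21 log units; beyond the scatter). The reading for compound 3 is a limit and not a number, so this step fixes only the smallest size the change can have, and its full size cannot be read. The position is therefore not indifferent to what it carries, and compound 1 remains the only compound shown with a number, while the series now has more than one compound at the limit: the limit of > 150000 nM in this assay, at which 2 of the 3 values shown sit.

The change from compound 1 to compound 3 brings in the methylene link, the carbonyl and the amide hydrogen together, and moves the fluorine from the 4-fluorophenyl to the 3-fluorophenyl pattern, so the compounds shown cannot assign the step to any one of these. A benzyl group on the same nitrogen, or a simple phenyl ring without fluorine, would help separate the effect of the longer chain from that of the amide and the fluorine.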